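The source may report more compounds than this note shows. Statements on the series, on what has been measured and on what is new or still open speak of the compounds shown alone.

Of the compounds shown here, two built on one shared core have so far been tested in a functional assay on T-24 cells (Homo sapiens) for antiproliferative activity, read by sulforhodamine B assay, with a stated time of 72 h; a lower number here means a stronger inhibitor, a higher number a weaker inhibitor. Compound 1 `C=CCOC(=O)C1=C2C(=NC1=O)c1cccc3c(SCCC)ccc2c13` gives 13100 nM, the lower of the two numbers, and compound 2 `CCCSC(=O)COC(=O)C1=C2C(=NC1=O)c1cccc3c(SCCC)ccc2c13` gives 79100 nM. For the measured compounds named here, the one measured step, a 6.0-fold higher number from compound 1 to compound 2 (0.78 log units; beyond the scatter), puts (propylsulfanyl)carbonyl in place of vinyl on a saturated chain carbon bound to an oxygen next to a carbonyl group. It is modest but beyond the scatter.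

Compound 3 `C=CCOC(=O)C1=C2C(=NC1=O)c1cccc3c(SCC=C)ccc2c13` differs from compound 1 at another place: vinyl in place of ethyl on a saturated chain carbon bound to a sulfur. Put another way, the propylsulfanyl of compound 1 becomes allylsulfanyl in compound 3. Going by the values given here, no measured step touches that place, so a 6.0-fold higher number from compound 1 to compound 2 (0.78 log units; beyond the scatter) bears on it only indirectly, showing that a change at a different chain can move the number in this assay. With so little evidence, no shift in either direction beyond the scatter is expected. The step is estimated as a 1.1-fold lower number from compound 1 to compound 3 (0.04 log units; within the scatter). For compound 3 the estimated value is 12000 nM, with an expected range from 5500 nM to 27000 nM.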

Compound 3, half-maximal inhibitory concentration: 6600 nM
The estimate for compound 3 lay 1.8-fold (0.26 log units) above the measured number, and the stated range covers the measured number.
By their numbers in this assay, from the lowest: compounds 3 and 1 (each within the scatter of the next); then compound 2.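

In this assay, for the compounds shown here, the first measured change at the chain on sulfur is a 2.0-fold lower number from compound 1 to compound 3 (0.30 log units; within the scatter), so propylsulfanyl and allylsulfanyl cannot be told apart here. Vinyl in place of ethyl on a saturated chain carbon bound to a sulfur keeps the same count of heavy atoms and adds a double bond outside aromatic rings, and that double bond does not move the number beyond the scatter. Going by these compounds alone, the only earlier step, which lay at the other chain, was beyond the scatter, whereas this one is not, so for now the sulfur chain tolerates this one small swap without a clear shift in the number. Nothing measured on these compounds explains the result, and no separate data bear on it.

The compounds shown leave open whether a longer chain, a benzyl group or an amine on the sulfur would shift the number beyond the scatter. They also leave open whether allylsulfanyl would read the same alongside the (propylsulfanyl)carbonyl chain of compound 2 as it does alongside the allyl chain of compound 1.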